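This account rests on a few compounds, and the source may have more. Where it says the series, first, only, none or still open, it means among the compounds named here.

Results so far in an ADME assay on microsomes from liver (Mus musculus) for metabolic stability, read by LC-MS, using NADPH, with a stated time of 10 min, tested at 0.1 uM; a higher number here means faster removal of the compound, a lower number slower removal

- compound 1 `COc1ccc(F)cc1N1C(=O)CSC1c1cccc(C(=O)NCCCCc2ccccc2)c1` gives 2250 mL.min-1.g-1
- compound 2 `C#Cc1cc(C(=O)NCCCCc2ccccc2)cc(C2SCC(=O)N2c2ccccc2OC)c1` gives 2490 mL.min-1.g-1
- compound 3 `Cc1ccnc(N2C(=O)CSC2c2cccc(C(=O)NCCCCn3cccn3)c2)c1` gives 392 mL.min-1.g-1

Compound 1 and compound 2 lie within the scatter of each other, while compound 3 has a clearly lower number, beyond the scatter.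

Going from compound 1 to compound 4 (`O=C(NCCCCc1ccccc1)c1cccc(C2SCC(=O)N2c2cccc(F)c2)c1`) means one change (hydrogen in place of methoxy on an aromatic carbon): hydrogen in place of methoxy on an aromatic carbon, ortho to a large group and para to a fluoro group. Thus 5-fluoro-2-methoxyphenyl becomes 3-fluorophenyl. Going by the values given here, no measured pair shows this change alone, so the data give no direct size for it. In this assay a small downward step is expected (a 1.2-fold lower number from compound 1 to compound 4 (0.07 log units; within the scatter)), not beyond the scatter. Compound 4 is expected to read 1900 mL.min-1.g-1 with a likely range of 900 mL.min-1.g-1 to 3500 mL.min-1.g-1 when measured.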

Compound 4, intrinsic clearance in microsomes: 2740 mL.min-1.g-1
The estimate for compound 4 lay 1.4-fold (0.16 log units) below the measured number; the range from low to high includes it.
By their numbers in this assay, from the lowest: compound 3; then compounds 1, 2 and 4 (each within the scatter of the next).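

In this assay, replacing methoxy with hydrogen, so that 5-fluoro-2-methoxyphenyl becomes 3-fluorophenyl, gives a 1.2-fold higher number from compound 1 to compound 4 (0.09 log units; within the scatter). Going by these compounds alone, this is the first single-place comparison, and it shows that this one swap at this position does not move the number outside the usual scatter. No measurement here offers a reason for this result.

As far as these compounds go, whether a different group at this position, such as an amine, a carboxylic acid or a longer ether chain, would shift the number remains open. Also open, from the compounds shown here alone, is whether the same swap would behave alike in a ring lacking the fluoro group.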